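From 2-chlorophenyl to 3-chlorophenyl in a cytotoxic series

A few compounds are considered here, and "the series" means these few. Any claim that something is new, unique, unknown or untested is made for them only; others in the source may bear on it.

Of the compounds shown here, three sharing one core have been measured so far in a functional assay on MCF7 cells (Homo sapiens) for cytotoxicity, read by ELISA, with a stated time of 4 days (a lower number here means a stronger inhibitor, a higher number a weaker inhibitor), as the test. Compound 1 `Cc1ccccc1-c1cc(-c2ccoc2)cc(-c2ccc(Cl)s2)n1` gives 1430 nM as the lowest number of the set, and compound 2 `Cc1cccc(-c2cc(-c3ccoc3)cc(-c3ccc(Cl)s3)n2)c1` gives 3990 nM for comparison. Compound 3 `Clc1ccc(-c2cc(-c3ccoc3)cc(-c3ccccc3Cl)n2)s1` gives 7360 nM and stands at the weak end together with compound 2, with a 1.8-fold higher number from compound 2 to compound 3 (0.27 log units; within the scatter) as the gap between them. Compound 4 `Clc1cccc(-c2cc(-c3ccoc3)cc(-c3ccc(Cl)s3)n2)c1` has not yet been measured. It has the same atoms as compound 3, joined differently: 3-chlorophenyl in place of 2-chlorophenyl on an aromatic carbon amounts to 3-chlorophenyl in place of 2-chlorophenyl on an aromatic carbon next to the ring nitrogen.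

The closest guide is the matching shift of a methyl group, where 3-methylphenyl in place of 2-methylphenyl gave a 2.8-fold higher number from compound 1 to compound 2 (0.45 log units; beyond the scatter) as a modest step. Chloro in place of methyl gave a 5.1-fold higher number from compound 1 to compound 3 (0.71 log units; beyond the scatter) as another modest step, so a small change at this group can move the number beyond the scatter. Among the compounds with values here, only one pair shows a shift of this kind, and it carries methyl and not chloro, so a smaller step in the same direction is expected in this assay here. The estimate is a 1.4-fold higher number from compound 3 to compound 4 (0.13 log units; within the scatter) as a rough guide. Compound 4 is expected at 10000 nM with an estimated range from 3500 nM to 28000 nM for repeat measurements.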

Compound 4, half-maximal inhibitory concentration: 2920 nM
Estimate against measurement, compound 4: 3.4-fold (0.53 log units) above, and the stated range ends above it.
By their numbers in this assay, from the lowest: compound 1; then compounds 4, 2 and 3 (each within the scatter of the next, the first and the last beyond it).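

Shifting the chlorine from 2-chlorophenyl to 3-chlorophenyl runs against the methyl shift in this assay: the chlorine move gives a 2.5-fold lower number from compound 3 to compound 4 (0.40 log units; beyond the scatter), while the methyl move gave a 2.8-fold higher number from compound 1 to compound 2 (0.45 log units; beyond the scatter), so the effect of this shift depends on which group is moved. The exchange of chloro for methyl also depends on where it is made, since between the 3-substituted phenyl groups it gives only a 1.4-fold lower number from compound 2 to compound 4 (0.14 log units; within the scatter), which leaves compound 2 and compound 4 indistinguishable, and the comparison across the two pairs makes this plain: the same change on two cores in this assay, a 5.1-fold higher number (0.71 log units; beyond the scatter) from compound 1 to compound 3 and a 1.4-fold lower number (0.14 log units; within the scatter) from compound 2 to compound 4, 7.0-fold (0.85 log units) apart, beyond the scatter of two such steps. Compound 4 does not displace the 2-methylphenyl compound, with a 2.0-fold higher number from compound 1 to compound 4 (0.31 log units; beyond the scatter), so compound 1 keeps the lowest number of the four.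

Each direction of the shift rests on a single pair, and these compounds cannot say why the chlorine and the methyl move in opposite ways. Open too, from the compounds shown here alone, is how a 4-chlorophenyl group, or a methoxy group or an amine on this phenyl ring, would behave.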